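The compounds below may be only part of what the source reports. "The series", "measured", "known", "first", "only" and "open" are said of these compounds alone.

In a functional assay on L02 cells (Homo sapiens) for inhibition, read by Griess assay, with stated times of 1 h and 24 h (on this read-out lower numbers stand for stronger inhibition and higher numbers for weaker inhibition), compound 3 `Brc1cccc(Nc2nc(/C=C/c3ccccc3)nc3ccsc23)c1` gives > 1000000 nM, which is a limit of the assay and not a number. Compound 1 `CNc1nc(/C=C/c2ccccc2)nc2ccsc12` gives > 1000000 nM, also a limit. Compound 2 `CCCCNc1nc(/C=C/c2ccccc2)nc2ccsc12` gives > 1000000 nM, again a limit. All three sit at the limit of > 1000000 nM in this assay, at which 3 of the 3 values shown sit, so the steps a step that the two limits leave unreadable from compound 1 to compound 2, a step that the two limits leave unreadable from compound 1 to compound 3 and a step that the two limits leave unreadable from compound 2 to compound 3 stay unreadable and show nothing about size or direction. Compound 4 `COc1ccc(Nc2nc(/C=C/c3ccccc3)nc3ccsc23)cc1` differs from compound 3 by 4-methoxyphenyl in place of 3-bromophenyl on a nitrogen on an aromatic ring. Going by the values given here, no measured step bears on this change, and the expectation for the step of a number no higher from compound 3 to compound 4 (the limit leaves the size open) is therefore no change beyond the scatter, most likely a further limit. Compound 4 is expected to give 1000000 nM, estimated between 100000 nM and 5000000 nM.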

Compound 4, half-maximal inhibitory concentration: > 1000000 nM
Compound 4: only a limit was reported (the forecaster's own chance of this, stated with the estimate: 80%); the middle value sits exactly at the limit.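

Compound 4 gives > 1000000 nM, which is a limit, so its steps from compound 1, compound 2 and compound 3 cannot be read: the limit of > 1000000 nM in this assay, at which 4 of the 4 values shown sit.

The compounds shown leave open which group on the nitrogen, if any, would give a measurable value in this assay.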